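Lengthening the Amine Chain on Compound 2

The compounds below may be only part of what the source reports. "The series", "measured", "known", "first", "only" and "open" are said of these compounds alone.

Compound 1 `CCCCCCCCNC1=CC(=O)C(C(C)(C)C)=CC1=O` and compound 3 `CCCCNC1=CC(=O)C(C(C)(C)C)=CC1=O` share one core. Among the compounds with values here, in a functional assay on NCI-H460 cells (Homo sapiens) for cytotoxicity, read by MTT assay, with a stated time of 72 h (a higher number here means a weaker inhibitor, a lower number a stronger inhibitor), compound 1 gives 70000 nM, while compound 3 gives 36000 nM; the step of a 1.9-fold lower number from compound 1 to compound 3 (0.29 log units; within the scatter) is the only measured step in this set. Compound 2 `CCCCNC1=CC(=O)C(C[C@]2(C)[C@@H](C)CC[C@]3(C)C(C)=CCC[C@@H]23)=CC1=O` carries a different core. In this assay, as far as these compounds go, compound 2 gives only a limit, > 100000 nM, so its true number is unknown. Compound 4 `CCCCCCCCNC1=CC(=O)C(C[C@]2(C)[C@@H](C)CC[C@]3(C)C(C)=CCC[C@@H]23)=CC1=O` differs from compound 2 by butyl in place of hydrogen on a saturated chain carbon, four bonds along the chain from an amine nitrogen. The measured step runs in the opposite sense and stays within the scatter, so the change is expected to leave the number roughly unchanged, and since compound 2 already sits at the limit of > 100000 nM in this assay, at which 1 of the 3 values shown sits, compound 4 is expected to do the same. For compound 4 the estimate is 150000 nM, between 60000 nM and 400000 nM. This corresponds to an expected step that the limit leaves unreadable from compound 2 to compound 4.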

Compound 4, half-maximal inhibitory concentration: > 100000 nM
Compound 4 gave a limit, no number (the forecaster's own chance of this, stated with the estimate: 70%); the middle value does not contradict the limit.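

In this assay compound 4 gives only a limit, > 100000 nM and no number. Within the data shown here, compound 2 also gives only a limit, so no step between compound 2 and compound 4 can be read. The compounds shown leave open how far butyl in place of hydrogen moves the number on the core of compound 2.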